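Putting phenoxy on the carbonyl carbon of compound 3

A few compounds are considered here, and "the series" means these few. Any claim that something is new, unique, unknown or untested is made for them only; others in the source may bear on it.

Compound 1 (`CCCN(CCC)C(=O)c1cncc(C(=O)N[C@@H](CC(=O)O)C(=O)CSCc2ccc(F)cc2)c1`) gives > 100000 nM as a limit of the assay
Compound 2 (`O=C[C@H](CC(=O)O)NC(=O)c1cncc(S(=O)(=O)NC2CC2)c1`) gives 57000 nM as a measured value
Compound 3 (`O=C(O)C[C@H](NC(=O)c1cncc(S(=O)(=O)NC2CC2)c1)C(=O)CNCc1c(F)cccc1F`) gives 53000 nM as a measured value

All three compounds were tested in a functional assay on NT2 cells (Homo sapiens) for inhibition (a lower number here means a stronger inhibitor, a higher number a weaker inhibitor), as a measure of inhibition. Compound 3 stands level with compound 2, since their two values lie within the scatter of each other. Compound 4 (`O=C(O)C[C@H](NC(=O)c1cncc(S(=O)(=O)NC2CC2)c1)C(=O)Oc1ccccc1`) differs from compound 3 by a single change on a carbonyl carbon (phenoxy in place of ((2,6-difluorobenzyl)amino)methyl on a carbonyl carbon), with phenoxy in place of ((2,6-difluorobenzyl)amino)methyl. Within the data shown here, only one measured step bears on this carbonyl carbon (a 1.1-fold lower number from compound 2 to compound 3 (0.03 log units; within the scatter)), and it stayed within the scatter even though a sizeable group replaced hydrogen there. Phenoxy itself has not been measured in this series, so that single step is a thin guide and the range must stay wide. No step beyond the scatter is therefore expected in this assay for this change. The expected step is small (a 1.0-fold higher number from compound 3 to compound 4 (0.02 log units; within the scatter)). Compound 4 is expected at about 55000 nM (estimated range 20000 nM to 150000 nM).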

Compound 4, half-maximal inhibitory concentration: 4300 nM
Beside the measured number, compound 4's estimate is 13-fold (1.11 log units) above it, outside the stated range (below it).
By their numbers in this assay, from the lowest: compound 4; then compounds 3 and 2 (each within the scatter of the next). At a limit, above all of these: compound 1.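

In this assay this carbonyl carbon had seemed to respond little to what was attached, since a 1.1-fold lower number from compound 2 to compound 3 (0.03 log units; within the scatter) stayed within the scatter. Phenoxy changes that picture: in place of ((2,6-difluorobenzyl)amino)methyl it gives a 12-fold lower number from compound 3 to compound 4 (1.09 log units; beyond the scatter), and in place of hydrogen it gives a 13-fold lower number from compound 2 to compound 4 (1.12 log units; beyond the scatter), so the group on this carbon can matter a great deal. Nothing measured here accounts for the size of these steps.

From the compounds shown here alone, it remains open whether the gain depends on the linking oxygen or on the aromatic ring, a question that a methoxy group, with the oxygen but no ring, or a plain benzyl group, with a ring but no oxygen, would help to settle. Going by these compounds, how fluorine atoms on the phenoxy ring, as in 2,6-difluorophenoxy, would shift the number is also open.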